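Fluoro in Place of Nitro: An Expected Recovery

The source may hold more compounds than are shown below. What is called first, only, known or untested is meant among the compounds shown, and "the series" means these compounds.

Compound 2 `CC(=O)c1ccc(OCc2ccccc2[N+](=O)[O-])cc1` gives 284 nM in an assay on isolated protein for inhibition of Amine oxidase [flavin-containing] B (Homo sapiens), read by Amplex Red, with a stated time of 15 min (a lower number here means a stronger inhibitor, a higher number a weaker inhibitor), the highest number among the three measured compounds. Compound 1 `CC(=O)c1ccc(OCc2ccccc2C)cc1` gives 77.1 nM, and compound 3 `CC(=O)c1ccc(OCc2ccc([N+](=O)[O-])cc2)cc1` gives 96.5 nM. The change now considered is fluoro in place of nitro on an aromatic carbon, which produces compound 4 `CC(=O)c1ccc(OCc2ccccc2F)cc1`. Among the measured compounds shown here, the one measured step that bears on this is a 3.7-fold higher number from compound 1 to compound 2 (0.57 log units; beyond the scatter), showing that introducing the nitro group at this position raised the number by a modest amount. Taking the nitro away again and placing fluoro there is therefore expected to lower the number, roughly undoing that step, though the exact size is uncertain. For compound 4 the expected value in this assay is 90 nM, with a range from 40 nM to 200 nM, meaning a step of a 3.2-fold lower number from compound 2 to compound 4 (0.50 log units; beyond the scatter).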

Compound 4, half-maximal inhibitory concentration: 56.9 nM
Estimate against measurement, compound 4: 1.6-fold (0.20 log units) above; measured number inside the range.
By their numbers in this assay, from the lowest: compounds 4, 1 and 3 (each within the scatter of the next); then compound 2.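

Placing fluoro on this aromatic carbon gives a 5.0-fold lower number from compound 2 to compound 4 (0.70 log units; beyond the scatter), so this position can carry a substituent with a low number, and the high number of compound 2 goes with the nitro group in particular. Fluoro and methyl cannot be told apart here, given a 1.4-fold lower number from compound 1 to compound 4 (0.13 log units; within the scatter), which makes two small groups that behave alike at this place. No measurement at hand explains why nitro stands apart from them. Still open, going by these compounds, is where an amine, a methoxy group or a chlorine at this same carbon would fall. On these data alone, the effect of fluoro on another carbon of this ring also remains open.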